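The compounds below may be only part of what the source reports. "The series", "measured", "known", "first", "only" and "open" are said of these compounds alone.

Measured so far:
compound 1 `CS(=O)(=O)CCCn1c(Cn2c(=O)n(C3CC3)c3ccncc32)nc2nc(Cl)ccc21` — > 50000 nM
compound 2 `CS(=O)(=O)CCCn1c(Cn2c(=O)n(C3CC3)c3ccncc32)cc2cc(Cl)ccc21` — > 50000 nM
compound 3 `O=c1n(Cc2cc3cc(Cl)ccc3n2CCCC(F)(F)F)c2cnccc2n1C1CC1` — > 50000 nM

In an ADME assay on HeLa cells (Homo sapiens) for cytotoxicity, read by ATP content, with a stated time of 3 days (a higher number here means that more compound is tolerated, a lower number that less compound is tolerated), compound 1 gives > 50000 nM, which is a limit of the assay and not a number. Compound 2 gives > 50000 nM in this assay, again a limit. Compound 3 gives > 50000 nM in this assay, also a limit. Compound 2 therefore stands only at a limit, and the two further values shown are limits as well: the limit of > 50000 nM in this assay, at which 3 of the 3 values shown sit.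

Among the compounds with values here, the one measured step, a step that the two limits leave unreadable from compound 2 to compound 3, trifluoromethyl in place of methylsulfonyl on a saturated chain carbon, three bonds along the chain from an aromatic nitrogen, cannot be sized from two limits.

Compound 4 `CS(=O)(=O)CCCn1c(Cn2c(=O)n(C3CC3)c3ccncc32)cc2cc(C(F)(F)F)ccc21` differs from compound 2 by trifluoromethyl in place of chloro on an aromatic carbon. Within the data shown here, no measured step touches this aromatic position; the only measured step, which also brings in trifluoromethyl though on a chain carbon, stays unreadable. With every value at the limit, the expectation for compound 4 is that it is tolerated up to the same limit, the step that the limit leaves unreadable from compound 2 to compound 4 being expected to show no change beyond the scatter. Compound 4 is estimated at 70000 nM, within 30000 nM to 200000 nM, most likely reported again as a limit.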

Compound 4, half-maximal cytotoxic concentration: > 50000 nM
Compound 4: only a limit was reported; the forecaster's own chance of this, stated with the estimate: 85%; the middle value does not contradict the limit.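

Compound 2 and compound 4 both stand at a limit, so trifluoromethyl in place of chloro on an aromatic carbon gives no readable step: the limit of > 50000 nM in this assay, at which 4 of the 4 values shown sit.

The compounds shown leave open where the half-maximal cytotoxic concentration of any of them lies in this assay, and whether any single change in the series shifts it.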